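A few compounds are considered here, and "the series" means these few. Any claim that something is new, unique, unknown or untested is made for them only; others in the source may bear on it.

Series notes: cyclohexylidene-linked aryl ethers carrying a heteroaryl amide.

Compound 1 `O=C(NC1CCC(=Cc2cccc(Oc3ccc(C(F)(F)F)cn3)c2)CC1)c1cccnc1` gives 414 nM in an assay for inhibition of Fatty-acid amide hydrolase 1 (Homo sapiens), read by fluorescence, with stated times of 1 min and 50 min; on this read-out higher numbers stand for weaker inhibition and lower numbers for stronger inhibition. Within the data shown here, compound 2 `Nc1ncc(C(=O)NC2CCC(=Cc3cccc(Oc4ccc(C(F)(F)F)cn4)c3)CC2)cc1Cl` gives 4 nM in this assay and stands at the lowest of the two numbers measured so far, well separated from compound 1 by a 100-fold lower number from compound 1 to compound 2 (2.01 log units; beyond the scatter). Among the measured compounds shown here, that single step, 6-amino-5-chloropyridin-3-yl in place of pyridin-3-yl on the carbonyl carbon, is the only measured change.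

Compound 3 `O=C(NC1CCC(=Cc2cccc(Oc3ccc(C(F)(F)F)cn3)c2)CC1)c1ccc(-n2cccn2)nc1` is not yet measured. It differs from compound 2 by 6-(1H-pyrazol-1-yl)pyridin-3-yl in place of 6-amino-5-chloropyridin-3-yl on a carbonyl carbon. For the measured compounds named here, no measured step covers this exchange; the one step known shows that substitution on the pyridine ring bearing the amide can move the number strongly, so a return part of the way toward compound 1 is expected rather than a further drop. Compound 3 is therefore estimated at 40 nM, with a range of 6 nM to 250 nM, which would mean a step of a 10-fold higher number from compound 2 to compound 3 (1.00 log units; beyond the scatter) in this assay.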

Compound 3, half-maximal inhibitory concentration: 6.7 nM
For compound 3 the middle estimate is 6.0-fold (0.78 log units) above the measured one; measured number inside the range.
By their numbers in this assay, from the lowest: compounds 2 and 3 (each within the scatter of the next); then compound 1.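

Adding a single substituent to the pyridine ring of compound 1 is enough to produce a large change in this assay: 1H-pyrazol-1-yl in place of hydrogen on an aromatic carbon gives a 62-fold lower number from compound 1 to compound 3 (1.79 log units; beyond the scatter). The 6-amino-5-chloropyridin-3-yl group is therefore not the only route to a low number, since a 1.7-fold higher number from compound 2 to compound 3 (0.22 log units; within the scatter), even though the entering group has no chlorine and 0 hydrogen-bond donors. Nothing available explains why two such different groups cannot be told apart in this assay.

The compounds shown leave open whether the amino group or the chlorine carries the step seen in compound 2. They also leave open how far the pyrazole ring itself matters, as against a methoxy group or a morpholine ring on the same pyridine.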